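Adding an ethyl group to compound 2

This account rests on a few compounds, and the source may have more. Where it says the series, first, only, none or still open, it means among the compounds named here.

Measured in a functional assay on SW480 cells (Homo sapiens) for antiproliferative activity, read by MTT assay, with a stated time of 48 h; on this read-out higher numbers stand for weaker inhibition and lower numbers for stronger inhibition:
- compound 1 `O=c1cc(-n2cc(-c3ccccc3)nn2)c2cc(Br)ccc2o1`: 6660 nM
- compound 2 `O=c1cc(-n2cc(COc3ccccc3)nn2)c2cc(Br)ccc2o1`: 4990 nM
- compound 3 `COC(=O)c1ccccc1OCc1cn(-c2cc(=O)oc3ccc(Br)cc23)nn1`: 20200 nM

Compound 2, at 4990 nM, stands level with compound 1 within the scatter, as a 1.3-fold lower number from compound 1 to compound 2 (0.13 log units; within the scatter) shows. Compound 4 `CCc1ccc(OCc2cn(-c3cc(=O)oc4ccc(Br)cc34)nn2)cc1` alters compound 2 in one place: ethyl in place of hydrogen on an aromatic carbon. Phenoxy becomes 4-ethylphenoxy. Within the data shown here, the nearest precedent is a 4.0-fold higher number from compound 2 to compound 3 (0.61 log units; beyond the scatter), where methoxycarbonyl replaces hydrogen on an aromatic carbon. Among the measured compounds shown here, the phenyl to phenoxymethyl step bears less directly, and no measured compound carries ethyl. This single precedent, from a different group, is thin evidence, so only a small rise, probably within the scatter, is expected. The step expected is a 1.3-fold higher number from compound 2 to compound 4 (0.11 log units; within the scatter). In this assay the estimate for compound 4 is 6500 nM, expected to fall between 2500 nM and 17000 nM.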

Compound 4, half-maximal inhibitory concentration: 10800 nM
Compound 4: middle estimate off by 1.7-fold (0.22 log units), on the low side; the measured number falls inside the stated range.
By their numbers in this assay, from the lowest: compounds 2, 1, 4 and 3 (each within the scatter of the next, the first and the last beyond it).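

In this assay, ethyl in place of hydrogen on the phenoxy ring gives a 2.2-fold higher number from compound 2 to compound 4 (0.34 log units; beyond the scatter). Until now, only methoxycarbonyl had shown such a rise, and ethyl has no hydrogen-bond donors or acceptors, so a group of only carbon on this ring can also weaken inhibition beyond the scatter. No available evidence explains this rise. The compounds shown leave open whether a methyl group, a longer chain such as butyl, or an amine at this same place would follow ethyl, and whether any group there could lower the number below that of compound 2.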